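Trifluoromethyl in place of nitro on a shared core

This account rests on a few compounds, and the source may have more. Where it says the series, first, only, none or still open, it means among the compounds named here.

Measured so far in a functional assay on DU-145 cells (Homo sapiens) for antiproliferative activity, read by MTT assay, with a stated time of 72 h; on this read-out lower numbers stand for stronger inhibition and higher numbers for weaker inhibition:
compound 1 `O=[N+]([O-])c1ccc(COc2ccc(Nc3ncnc4cc5c(cc34)OCCOCCO5)cc2)cc1` gives > 100000 nM
compound 2 `c1ccc(COc2ccccc2Nc2ncnc3cc4c(cc23)OCCOCCO4)cc1` gives > 100000 nM
compound 3 `FC(F)(F)c1ccc(COc2ccc(Nc3ncnc4cc5c(cc34)OCCOCCOCCOCCO5)cc2)cc1` gives 8800 nM

Compound 1 stands at the limit of > 100000 nM in this assay, at which 2 of the 3 values shown sit, so its value is a limit of this assay and not a number. Compound 2 rests at the same limit. Compound 3 alone gives a measured number, and it carries the trifluoromethyl group together with the longer chain in the macrocyclic loop of its core. Among the measured compounds shown here, no step between the measured compounds is counted here, so the three values can only be set side by side.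

Compound 4 `FC(F)(F)c1ccc(COc2ccc(Nc3ncnc4cc5c(cc34)OCCOCCO5)cc2)cc1` keeps the core of compound 1 and differs from it at one place: trifluoromethyl in place of nitro on an aromatic carbon. Compound 4 thus holds the trifluoromethyl of compound 3 on the shorter loop of compound 1.

The estimate for compound 4 in this assay is 20000 nM, with a range from 5000 nM to 100000 nM, because compound 3 gives 8800 nM with the same trifluoromethyl group. The step of an at least 5.0-fold lower number from compound 1 to compound 4 (0.69 log units; beyond the scatter) is expected to run toward stronger inhibition and beyond the scatter, though from a limit its true size cannot be fixed.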

Compound 4, half-maximal inhibitory concentration: > 100000 nM
Compound 4: only a limit was reported (the forecaster's own chance of this, stated with the estimate: 30%); middle value at least 5.0-fold (0.69 log units) away from the limit.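

In this assay compound 4 gives > 100000 nM, a limit of the assay and not a number. No new step can be read, since compound 1 and compound 4 both rest at a limit: the limit of > 100000 nM in this assay, at which 3 of the 4 values shown sit. The compounds shown leave open whether trifluoromethyl in place of nitro changes inhibition at all on this shared core.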